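Swapping an aryl thioether for a phenethyl thioether

The source may hold more compounds than are shown below. What is called first, only, known or untested is meant among the compounds shown, and "the series" means these compounds.

Measured compounds:
compound 1 `Nc1ccccc1NC(=O)/C=C/c1ccc(CSc2ccc(Cl)cc2)cc1` — 17.3%
compound 2 `Nc1ccccc1NC(=O)c1ccc(CSc2ccc(C(F)(F)F)cn2)cc1` — 16.5%

In a functional assay on HeLa cells (Homo sapiens) for inhibition, read by CCK-8 assay, with a stated time of 72 h, tested at 8 uM (on this read-out lower numbers stand for less inhibition of growth and higher numbers for more inhibition of growth at the one concentration tested), compound 1 gives 17.3% and compound 2 gives 16.5%. Compound 1 has the higher of the two numbers, but the gap to compound 2 lies within the scatter of repeated measurements, so the two compounds cannot be told apart on this read-out. Both sit in the low range of growth inhibition.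

Compound 3 `Nc1ccccc1NC(=O)/C=C/c1ccc(CSCCc2ccccc2)cc1` has not yet been tested in this assay. It differs from compound 1 by phenethyl in place of 4-chlorophenyl on a sulfur. Within the data shown here, no step between measured compounds is available to guide this change, so the expectation rests on the low, closely matched values of compounds 1 and 2 alone. The step of a number 2.3 percentage points lower from compound 1 to compound 3 (within the scatter) is expected to be small, with no clear direction beyond the scatter. Compound 3 is therefore estimated at 15%, within a range of 4% to 30%.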

Compound 3, percent growth inhibition at one concentration: 3.57%
Estimate against measurement, compound 3: 11.4 percentage points above, and the stated range ends above it.
By their numbers in this assay, from the lowest: compound 3; then compounds 2 and 1 (each within the scatter of the next).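

In this assay, among these compounds, phenethyl in place of 4-chlorophenyl on a sulfur gives a number 13.7 percentage points lower from compound 1 to compound 3 (beyond the scatter), the first step here that lies beyond the scatter. Compounds 1 and 2 differ in more than one place and could not isolate this position, whereas this pair shows that the group on the sulfur can alter growth inhibition even when both groups contain one six-membered aromatic ring of carbon only. No measurement at hand accounts for the lower number.

The single change removes the chlorine and also brings in the two-carbon link of phenethyl, so the compounds shown cannot separate these two differences. Going by these compounds, it remains open how phenyl or benzyl on the sulfur, or 4-chlorophenethyl, would compare with compound 1 and compound 3.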